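Cyclohexyl replaces pyrimidinyl on the amide nitrogen

The source may hold more compounds than are shown below. What is called first, only, known or untested is meant among the compounds shown, and "the series" means these compounds.

In an assay on HEK293 cells for agonist activity at transient receptor potential cation channel subfamily M member 8 (Homo sapiens), read by fluorescence and calcium flux, with a stated time of 15 min (on this read-out higher numbers stand for an effect only at larger amounts of compound and lower numbers for an effect already at smaller amounts), compound 1 `COc1ccc2oc(C(=O)N(Cc3cccs3)c3ccn[nH]3)cc2c1` gives 1.1 nM, compound 2 `Cc1ccc(OCC(=O)N(Cc2cccs2)c2c[nH]nc2C)cc1` gives 0.4 nM, and compound 3 `Cc1ccc(OCC(=O)N(Cc2cccs2)c2ncccn2)cc1` gives 3700 nM. Compound 3 stands highest of the three numbers, with compound 1 its nearest neighbour and compound 2 the furthest away. Compound 4 `Cc1ccc(OCC(=O)N(Cc2cccs2)C2CCCCC2)cc1` differs from compound 3 in one place: cyclohexyl in place of pyrimidin-2-yl on an amide-type nitrogen. Going by the values given here, the only measured step at the same position is a 9300-fold higher number from compound 2 to compound 3 (3.97 log units; beyond the scatter). A cyclohexyl group on this amide-type nitrogen has not been measured, so the size of the step is uncertain: the group that came with the large rise now leaves, yet the group that gave the low number does not come back. Compound 4 is therefore expected to show a 2.5-fold lower number from compound 3 to compound 4 (0.39 log units; beyond the scatter), with an estimate of 1500 nM and a range from 100 nM to 20000 nM.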

Compound 4, half-maximal effective concentration: 40000 nM
Compound 4: middle estimate off by 27-fold (1.43 log units), on the low side; measured number above the stated range.
By their numbers in this assay, from the lowest: compound 2; then compound 1; then compound 3; then compound 4.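

In this assay, cyclohexyl in place of pyrimidin-2-yl gives an 11-fold higher number from compound 3 to compound 4 (1.03 log units; beyond the scatter) and so moves further from the low numbers, even though the group that came with the large rise has gone. Set against 3-methyl-1H-pyrazol-4-yl, the same change gives a 100000-fold higher number from compound 2 to compound 4 (5.00 log units; beyond the scatter) and places both six-membered rings, aromatic or not, far above it on this amide-type nitrogen. Among these three groups, only 3-methyl-1H-pyrazol-4-yl goes with a low number.

Where a phenyl or an imidazolyl group on this nitrogen would fall remains open. Nothing available here explains these steps.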